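The compounds below may be only part of what the source reports. "The series", "measured", "known", "first", "only" and "open" are said of these compounds alone.

Three compounds share one core and are compared in a functional assay on HepG2 cells (Homo sapiens) for antiproliferative activity, read by MTT assay, with a stated time of 72 h; on this read-out higher numbers stand for weaker inhibition and lower numbers for stronger inhibition. Compound 1, `Cc1nn(C)c(Oc2cccc(F)c2)c1/C=N\CCCCCOc1cc2oc(=O)cc(C)c2cc1Cl`, gives in this assay 13400 nM. Compound 2, `Cc1nn(C)c(Oc2ccc(F)cc2)c1/C=N\CCCCCOc1cc2oc(=O)cc(C)c2cc1Cl`, returns in this assay only a limit, > 25000 nM, which is the boundary of what the test can report and not a measured number. The change between them is 4-fluorophenyl in place of 3-fluorophenyl on an oxygen on an aromatic ring, and it brings an at least 1.8-fold higher number from compound 1 to compound 2 (0.27 log units; that floor lies within the scatter); that the step is known only as a floor follows because the limit of > 25000 nM in this assay, at which 2 of the 3 values shown sit, is where compound 2 sits.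

Compound 3, `Cc1nn(C)c(Oc2cccc(F)c2)c1/C=N\CCCCCCOc1cc2oc(=O)cc(C)c2cc1Cl`, also returns in this assay only a limit, > 25000 nM, again a boundary rather than a number. The difference between the core of compound 1 and the core of compound 3 is not broken down here, as the two differ in more than one place.

Compound 4, `Cc1nn(C)c(Oc2ccc(F)cc2)c1/C=N\CCCCCCOc1cc2oc(=O)cc(C)c2cc1Cl`, is not yet measured. It stands to compound 3 as compound 2 stands to compound 1: the difference is 4-fluorophenyl in place of 3-fluorophenyl on an oxygen on an aromatic ring, and the surroundings of the place are the same in both pairs, so this is the same change seen a second time. Since compound 3 already sits at the boundary of this assay, and the earlier instance of the change moved compound 1 toward that same boundary, the step is expected to be a step that the limit leaves unreadable from compound 3 to compound 4, most likely leaving the read-out at a limit again. On that basis compound 4 is estimated at 35000 nM in this assay, within a range from 15000 nM to 90000 nM.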

Compound 4, half-maximal inhibitory concentration: 12500 nM
Estimate against measurement, compound 4: 2.8-fold (0.45 log units) above; measured number outside the range, below it.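

In this assay, putting 4-fluorophenyl in place of 3-fluorophenyl on the core of compound 3 gives an at least 2.0-fold lower number from compound 3 to compound 4 (0.30 log units; that floor lies within the scatter), whereas on the core of compound 1 the same swap gives an at least 1.8-fold higher number from compound 1 to compound 2 (0.27 log units; that floor lies within the scatter). The change therefore does not carry over from one core to the other in these two pairs, since its direction reverses and the two steps lie further apart than repeated measurements would be expected to scatter: the same change on two cores in this assay, an at least 1.8-fold higher number (0.27 log units; that floor lies within the scatter) from compound 1 to compound 2 and an at least 2.0-fold lower number (0.30 log units; that floor lies within the scatter) from compound 3 to compound 4, at least 3.7-fold (0.57 log units) apart, beyond the scatter of two such steps What this does not show is why the direction reverses or how large either step really is, and each step is known only as a floor, which on its own lies within the scatter, because one compound in each pair sits at a limit of the test: the limit of > 25000 nM in this assay, at which 2 of the 4 values shown sit.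

Going by these compounds, the true numbers for compound 2 and compound 3 remain open, as both are limits and not measured values. With only two pairs shown, it also remains open whether the reversal would persist with a longer chain, or whether a plain phenyl group or a chlorophenyl group on the same oxygen would follow either pair.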